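This account rests on a few compounds, and the source may have more. Where it says the series, first, only, none or still open, it means among the compounds named here.

Series notes. Compound 1 `O=C(CSC(=S)N[C@H]1CCOC1=O)Nc1ccc(Br)cc1` gives 67400 nM in a functional assay on EC9706 cells (Homo sapiens) for cytotoxicity, read by MTT assay, with a stated time of 72 h; a higher number here means a weaker inhibitor, a lower number a stronger inhibitor. Compound 2 `Cc1ccc(NC(=O)CSC(=S)N[C@H]2CCOC2=O)cc1` gives 93900 nM in this assay, the step being a 1.4-fold higher number from compound 1 to compound 2 (0.14 log units; within the scatter). For compound 3 `O=C(CSC(=S)N[C@H]1CCOC1=O)Nc1ccc(O)cc1` the assay this assay reports only a limit, > 128000 nM, which is the limit of > 128000 nM in this assay, at which 1 of the 3 values shown sits. Compound 3 therefore stands at a limit and not at a number, so the steps of an at least 1.8-fold higher number from compound 1 to compound 3 (0.27 log units; that floor lies within the scatter) and an at least 1.3-fold higher number from compound 2 to compound 3 (0.13 log units; that floor lies within the scatter) are floors only and say nothing beyond the scatter. Compound 4 `CCCCc1ccc(NC(=O)CSC(=S)N[C@H]2CCOC2=O)cc1`, not yet measured, differs from compound 3 by butyl in place of hydroxy on an aromatic carbon. Going by the values given here, the steps that bear on this place are a 1.4-fold higher number from compound 1 to compound 2 (0.14 log units; within the scatter) and an at least 1.3-fold higher number from compound 2 to compound 3 (0.13 log units; that floor lies within the scatter), neither of which leaves the scatter, and the two measured numbers at this place, for compound 1 and compound 2, sit close together. The step of an at least 1.5-fold lower number from compound 3 to compound 4 (0.17 log units; that floor lies within the scatter) is therefore expected to be small, with a number for compound 4 near those of compound 1 and compound 2 but with a real chance of another limit. Compound 4 is estimated at 85000 nM, within 35000 nM to 200000 nM in this assay.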

Compound 4, half-maximal inhibitory concentration: 44200 nM
The estimate for compound 4 lay 1.9-fold (0.28 log units) above the measured number, and the stated range covers the measured number.
By their numbers in this assay, from the lowest: compounds 4, 1 and 2 (each within the scatter of the next, the first and the last beyond it). At a limit, above all of these: compound 3.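

Going by these compounds alone, until now no step at this position left the scatter; in this assay, extending the methyl of the earlier compound, with propyl in place of hydrogen on a saturated chain carbon bound to an aromatic carbon, gives a 2.1-fold lower number from compound 2 to compound 4 (0.33 log units; beyond the scatter). Butyl in place of hydroxy gives an at least 2.8-fold lower number from compound 3 to compound 4 (0.46 log units; beyond the scatter), which is a floor and not a measured size, as it rests on a limit: the limit of > 128000 nM in this assay, at which 1 of the 4 values shown sits. Butyl in place of bromo, by contrast, gives only a 1.5-fold lower number from compound 1 to compound 4 (0.18 log units; within the scatter), so these two groups are not told apart here.

From the compounds shown here alone, whether a longer chain such as hexyl would lower the number further at this position remains open, since one modest step does not establish a dependence on chain length. Where an amine or a carboxylic acid would fall at this position also remains open.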